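Swapping Isopropyl for Methyl on Compound 2

The source may hold more compounds than are shown below. What is called first, only, known or untested is meant among the compounds shown, and "the series" means these compounds.

In a functional assay on A549 cells (Homo sapiens) for antiproliferative activity, read by CCK-8 assay, with a stated time of 72 h (on this read-out lower numbers stand for stronger inhibition of growth and higher numbers for weaker inhibition of growth), compound 1 `CCC1C(=O)N(C)c2cnc(Nc3ccc(S(=O)(=O)NC)cc3)nc2N1c1ccn(C)n1` gives 12600 nM and compound 2 `CCC1C(=O)N(C)c2cnc(-n3ccc4cc(C(=O)NC(C)C)ccc43)nc2N1c1ccn(C)n1` gives 22000 nM here, so these two numbers lie within the usual scatter of each other. Compound 3 `CCC1C(=O)N(C)c2cnc(Nc3ccc(S(=O)(=O)NCCO)cc3)nc2N1c1ccn(C)n1` is recorded as "not active" (no number reported) with no number at all. Compound 2 therefore has no clear place apart from compound 1. Compound 4 `CCC1C(=O)N(C)c2cnc(-n3ccc4cc(C(=O)NC)ccc43)nc2N1c1ccn(C)n1` brings one change methyl in place of isopropyl on an amide-type nitrogen to compound 2, methyl in place of isopropyl on an amide-type nitrogen. Among the compounds with values here, no measured pair shows what such a swap does, so no shift beyond the scatter is expected. The estimated change a 1.1-fold lower number from compound 2 to compound 4 (0.04 log units; within the scatter) has no clear direction. In this assay the expected value for compound 4 is 20000 nM with a range from 8000 nM to 50000 nM as the estimated span.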

Compound 4, concentration for 50% growth inhibition: 43100 nM
Beside the measured number, compound 4's estimate is 2.2-fold (0.33 log units) below it; the measured number falls inside the stated range.
By their numbers in this assay, from the lowest: compounds 1, 2 and 4 (each within the scatter of the next, the first and the last beyond it).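

In this assay, within the data shown here, this is the first measured swap on the amide-type nitrogen: methyl in place of isopropyl gives a 2.0-fold higher number from compound 2 to compound 4 (0.29 log units; within the scatter). Removing two carbons from this group therefore produces no change beyond the usual scatter, so this pair gives no sign that the choice between these two groups matters here. No supporting measurement offers a reason for this result. Still open, on these data alone, is whether a longer chain, a cyclohexyl ring, or a group carrying an amine or a carboxylic acid on this nitrogen would give a clear shift from compound 2.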